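The source may report more compounds than this note shows. Statements on the series, on what has been measured and on what is new or still open speak of the compounds shown alone.

Compound 1, `CCC[C@H](CCn1cncn1)c1ccc(C)cc1`: 45.7 ug/mL
Compound 2, `CCCC[C@H](CCn1cncn1)c1ccc(OC)cc1`: 34.5 ug/mL

Both compounds were run in an ADME assay on HEp-2 cells (Homo sapiens) for cytotoxicity, read by MTT assay, with a stated time of 3 days; on this read-out lower numbers stand for higher toxicity in this test and higher numbers for lower toxicity in this test. Compound 2 gives 34.5 ug/mL in this assay; compound 1 gives 45.7 ug/mL, and the two numbers lie within the scatter of each other, so the pair shows no separation. Compound 2 therefore stands in a single band with compound 1, and the measured set offers no spread from which a trend could be read.

Compound 3, `CCCC[C@H](CCn1cncn1)c1ccc(C)cc1`, remains to be measured in this assay. It differs from compound 2 in one place: methyl in place of methoxy on an aromatic carbon. Among the measured compounds shown here, no step between measured compounds covers this exchange, so its size in this assay is not known from the data. For the measured compounds named here, the one measured compound that also carries a methyl on the ring, compound 1, gives 45.7 ug/mL, a number within the scatter of compound 2. With nothing in the measured set pointing either way, the expectation for this assay is no step beyond the scatter, in either direction. Compound 3 is expected to give 40 ug/mL, with a range from 20 ug/mL to 80 ug/mL. The step this estimate means, a 1.2-fold higher number from compound 2 to compound 3 (0.06 log units; within the scatter), is expected to remain within the scatter.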

Compound 3, half-maximal cytotoxic concentration: 23.7 ug/mL
The estimate for compound 3 lay 1.7-fold (0.23 log units) above the measured number; low and high end bracket the measured number.
By their numbers in this assay, from the lowest: compounds 3, 2 and 1 (each within the scatter of the next).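

In this assay methyl in place of methoxy on an aromatic carbon, para to a large group, gives a 1.5-fold lower number from compound 2 to compound 3 (0.16 log units; within the scatter) and so this exchange now has a measured size, one that stays within the scatter on this core. Methyl in place of hydrogen on a saturated chain carbon, four bonds along the chain from an aromatic carbon, gives a 1.9-fold lower number from compound 1 to compound 3 (0.29 log units; within the scatter) and so the chain position, read with the ring methyl held fixed, also shows no separation, leaving all three compounds in a single band. Nothing measured here bears on why either step has the size it has.

The compounds shown leave open whether a ring group other than methyl or methoxy, such as a chlorine, a nitrile or an amine, would give a step beyond the scatter at this place on the shared core. Also open, from the compounds shown here alone, is whether a longer chain would separate from these compounds in this assay or would stay in the same band.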